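The source may hold more compounds than are shown below. What is called first, only, known or untested is meant among the compounds shown, and "the series" means these compounds.

Compound 3 `Cc1cc(C)c(S(=O)(=O)N2CCC(N3CCCCC3)CC2)c(C)c1` gives 2200 nM in a functional assay on DLD-1 cells (Homo sapiens) for antiproliferative activity, read by CellTiter-Glo, with a stated time of 72 h (on this read-out lower numbers stand for stronger inhibition and higher numbers for weaker inhibition), the highest number among the three measured compounds; compound 1 `Cc1cc(C)c(S(=O)(=O)N2CCC(N3CCC(c4ccccc4)CC3)CC2)c(C)c1` gives 865 nM and compound 2 `Cc1cc(C)c(S(=O)(=O)N2CCC(N3CCC(Cc4ccc(F)cc4)CC3)CC2)c(C)c1` gives 18 nM in this assay. Compound 4 `Cc1cc(C)c(S(=O)(=O)N2CCC(N3CCC(Cc4ccccc4F)CC3)CC2)c(C)c1` differs from compound 3 in one place: 2-fluorobenzyl in place of hydrogen on a saturated ring carbon. The step bearing most directly on this runs the other way, a 120-fold higher number from compound 2 to compound 3 (2.09 log units; beyond the scatter), with 4-fluorobenzyl as the leaving group; the smaller 2.5-fold higher number from compound 1 to compound 3 (0.41 log units; beyond the scatter) concerns phenyl directly on the saturated ring carbon, and a 48-fold lower number from compound 1 to compound 2 (1.68 log units; beyond the scatter) separates the two. Since 2-fluorobenzyl is close kin to the 4-fluorobenzyl of compound 2, compound 4 is expected to show a large downward step in this assay, a 55-fold lower number from compound 3 to compound 4 (1.74 log units; beyond the scatter), probably somewhat short of that seen for compound 2. Compound 4 is therefore estimated at 40 nM, range 10 nM to 200 nM.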

Compound 4, half-maximal inhibitory concentration: 74 nM
For compound 4 the middle estimate is 1.9-fold (0.27 log units) below the measured one, within the range that was stated.
By their numbers in this assay, from the lowest: compound 2; then compound 4; then compound 1; then compound 3.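

In this assay the large drop on this saturated ring carbon is not unique to the 4-fluorobenzyl group, since a 30-fold lower number from compound 3 to compound 4 (1.47 log units; beyond the scatter) comes with 2-fluorobenzyl and a 12-fold lower number from compound 1 to compound 4 (1.07 log units; beyond the scatter) shows that it also outperforms directly attached phenyl. The fluorine's place on the benzyl ring still matters modestly, with a 4.1-fold higher number from compound 2 to compound 4 (0.61 log units; beyond the scatter) as the step for 2-fluorophenyl in place of 4-fluorophenyl. No evidence here accounts for either step.
Unsubstituted benzyl and 3-fluorobenzyl remain open, so the contribution of fluorine cannot yet be separated from that of the benzyl group. A longer chain such as 2-phenylethyl is also untested in the compounds shown.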